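The source may hold more compounds than are shown below. What is called first, only, known or untested is meant among the compounds shown, and "the series" means these compounds.

Of the compounds shown here, three have been measured in a functional assay on UO-31 cells (Homo sapiens) for inhibition, read by sulforhodamine B assay, with a stated time of 48 h, tested at 10 uM; a higher number here means more inhibition of growth at the concentration tested, a lower number less inhibition of growth. Compound 1 `CC(=O)c1ccc(Nc2ccnc(SCC(=O)c3ccc(Br)cc3)n2)cc1` gives 38% in this assay. Compound 2 `CC(=O)c1cccc(Nc2ccnc(SCC(=O)c3ccc(-c4ccccc4)cc3)n2)c1`, which carries a phenyl at the same place on its outer ring but differs elsewhere in the core, gives 40% in this assay. Compound 3 `CC(=O)c1ccc(Nc2ccnc(SCC(=O)c3ccc(Cl)cc3)n2)cc1` gives 33% in this assay. For the measured compounds named here, the three numbers lie close together: the step of a number 5 percentage points lower from compound 1 to compound 3 (within the scatter) is small, and the gap between compound 3 and compound 2 likewise stays within the usual scatter, so no compound can be singled out as more or less active than the others.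

Compound 4 `CC(=O)c1ccc(Nc2ccnc(SCC(=O)c3ccc(-c4ccccc4)cc3)n2)cc1` is built from compound 3 by one change: phenyl in place of chloro on an aromatic carbon. Going by the values given here, the only measured step that touches the same position is the halogen swap from compound 1 to compound 3, and that step was within the scatter. Compound 2 shows what a phenyl at this position gives on a related core, and its number sits near that of compound 3. On this basis no shift beyond the scatter is expected in this assay, with at most a slight rise. The expected step of a number 7 percentage points higher from compound 3 to compound 4 (within the scatter) is small. Compound 4 is estimated at 40% in this assay, with a range from 28% to 52%.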

Compound 4, percent growth inhibition at one concentration: 27%
The estimate for compound 4 lay 13 percentage points above the measured number; the measured number lies below the stated range.
By their numbers in this assay, from the lowest: compounds 4, 3, 1 and 2 (each within the scatter of the next, the first and the last beyond it).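

At the position on the outer ring, phenyl in place of chloro gives in this assay a number 6 percentage points lower from compound 3 to compound 4 (within the scatter) and so cannot be told apart from no change, while phenyl in place of bromo gives a number 11 percentage points lower from compound 1 to compound 4 (beyond the scatter) and does pass beyond the scatter. Taken together, these steps show that a group of six heavy atoms is no better here than either halogen of a single heavy atom, and that the phenyl brings no rise in growth inhibition at this position. For the compounds shown here, the comparison on the nitrogen adds something the earlier compounds could not show: with the phenyl in place on the outer ring, 4-acetylphenyl in place of 3-acetylphenyl gives a number 13 percentage points lower from compound 2 to compound 4 (beyond the scatter) and so the place of the acetyl group on that ring matters in this assay.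

As far as these compounds go, it remains open whether a smaller or different group at the outer position, such as an amine, a carboxylic acid or a methoxy group, would move the number beyond the scatter on either acetyl arrangement. No measurement is at hand that explains any of these steps.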